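Methyl on the ring carbon of the phenylbutyl urea

A few compounds are considered here, and "the series" means these few. Any claim that something is new, unique, unknown or untested is made for them only; others in the source may bear on it.

Measured compounds:
- Compound 1 `Cc1cnn(C(=O)N2CCCCC2)c1`; in an assay on isolated protein for inhibition of Fatty-acid amide hydrolase 1 (Rattus norvegicus), with a stated time of 3 h (a higher number here means a weaker inhibitor, a lower number a stronger inhibitor), compound 1 reaches only a limit, > 1000 nM.
- Compound 2 `CC(C)(C)OC(=O)N1CCN(C(=O)n2cc(C#N)cn2)CC1`; in this assay compound 2 gives 55 nM.
- Compound 3 `O=C(NCCCCc1ccccc1)n1cccn1`; in this assay compound 3 gives 290 nM.

Among the numbers shown, compound 3 stands highest; compound 2 sits lower by a gap beyond the scatter, and the value of compound 1 is a limit, not a number (the limit of > 1000 nM in this assay, at which 1 of the 3 values shown sits). The step to compound 4 `Cc1cnn(C(=O)NCCCCc2ccccc2)c1` is methyl in place of hydrogen on an aromatic carbon. Going by the values given here, no measured pair shows this change alone; compound 1 also carries the methyl group but differs in the amide part as well, so its limit gives no direct read. In this assay a small step is expected, if anything towards a higher number, and possibly none beyond the scatter. Compound 4 is estimated at 400 nM, within 120 nM to 1500 nM, meaning an expected step of a 1.4-fold higher number from compound 3 to compound 4 (0.14 log units; within the scatter).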

Compound 4, inhibition constant: 550 nM
For compound 4 the middle estimate is 1.4-fold (0.14 log units) below the measured one; the measured number falls inside the stated range.
By their numbers in this assay, from the lowest: compound 2; then compounds 3 and 4 (each within the scatter of the next). At a limit, above all of these: compound 1.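

In this assay the first direct read of this change is a 1.9-fold higher number from compound 3 to compound 4 (0.28 log units; within the scatter) and so, on the phenylbutyl urea, 4-methyl-1H-pyrazol-1-yl and 1H-pyrazol-1-yl cannot be told apart. This ring carbon therefore accepts a methyl without a step beyond the scatter. Compound 4 also gives a measured number rather than a limit.

Going by these compounds, whether an ethyl group, an amine or a carboxylic acid on the same carbon would be accepted as well remains open. Nothing shown here bears on a cause for this step.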